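This account rests on a few compounds, and the source may have more. Where it says the series, first, only, none or still open, it means among the compounds named here.

For the measured compounds named here, compound 3 `CC(C)[C@@H](C(=O)Nc1ccc(C(=O)Nc2ccc(F)cc2N)cc1)c1ccccc1` gives 0% in an assay on isolated protein for inhibition of protein deacetylase HDAC6 (Homo sapiens), read by fluorescence, tested at 1 uM (a higher number here means more inhibition at the concentration tested (going by the name of the read-out), a lower number less inhibition), the lowest of the three numbers so far. Compound 2 `CC(C)(C(=O)Nc1ccc(C(=O)Nc2ccccc2N)cc1)c1ccccc1` gives 4% in this assay, within the scatter of compound 3, while compound 1 `CC(C)[C@@H](C(=O)Nc1ccc(C(=O)Nc2ccccc2N)cc1)c1ccccc1` gives 16%. Going by the values given here, the one single-change step measured, a number 16 percentage points lower from compound 1 to compound 3 (beyond the scatter), concerns a fluoro in place of hydrogen on an aromatic carbon, a different place from the change now considered. Compound 4 `Nc1cc(F)ccc1NC(=O)c1ccc(NC(=O)C2CC2c2ccccc2)cc1` differs from compound 3 by 2-phenylcyclopropyl in place of 2-methyl-1-phenylpropyl on a carbonyl carbon. Among the compounds with values here, no measured step touches this place, so the expectation rests on the low level of compound 3 alone: a step of a number 4 percentage points higher from compound 3 to compound 4 (within the scatter) is expected, none beyond the scatter. Compound 4 is therefore estimated at 4%, between 0% and 15%.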

Compound 4, a percentage reported as inhibition, at one concentration (the size of the read-out at that concentration, not a potency): 0%
Estimate against measurement, compound 4: 4 percentage points above, within the range that was stated.
By their numbers in this assay, from the lowest: compounds 3, 4 and 2 (each within the scatter of the next); then compound 1.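

Putting 2-phenylcyclopropyl in place of 2-methyl-1-phenylpropyl on the carbonyl carbon gives no change at the digits printed from compound 3 to compound 4 (within the scatter) in this assay. With compound 3 already at 0%, this step could reveal a rise but not a further fall, and no rise appears. Nothing available explains this result.

On these data alone, how 2-phenylcyclopropyl reads on the core without the fluoro remains open, since any gain or loss may be hidden at so low a level. So does the reading of a chain ending in an amine or a carboxylic acid at this place.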